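This account rests on a few compounds, and the source may have more. Where it says the series, first, only, none or still open, it means among the compounds named here.

The series shares the core of compound 1 `CCOC(=O)CCSc1nc2cc(-n3nc(C(C)(C)C)sc3=O)c(F)cc2s1`, which in an assay on isolated protein for inhibition of protoporphyrinogen oxidase (Homo sapiens), read by capillary electrophoresis (on this read-out lower numbers stand for stronger inhibition and higher numbers for weaker inhibition), gives 9260 nM. Compound 2 `CCOC(=O)CCCSc1nc2cc(-n3nc(C(C)(C)C)sc3=O)c(F)cc2s1` gives 8670 nM in this assay; the step of a 1.1-fold lower number from compound 1 to compound 2 (0.03 log units; within the scatter) lies within the scatter, so on the two numbers available compound 2 and compound 1 stand at the same level. Compound 3 `C#CCSc1nc2cc(-n3nc(C(C)(C)C)sc3=O)c(F)cc2s1` carries the change (ethynyl in place of 2-(ethoxycarbonyl)ethyl on a saturated chain carbon bound to a sulfur). Among the measured compounds shown here, the only measured step, the one that lengthened the chain while keeping the ester, moved the number by less than the scatter, and it bears only weakly on a change that removes the ester chain altogether and leaves a propargyl group; no direct precedent for that group exists. The expected step of a 1.1-fold lower number from compound 2 to compound 3 (0.03 log units; within the scatter) is therefore none beyond the scatter, with a wide range to cover the untested change. Compound 3 is expected to give about 8000 nM, between 2500 nM and 25000 nM.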

Compound 3, inhibition constant: 9730 nM
Estimate against measurement, compound 3: 1.2-fold (0.09 log units) below; the measured number falls inside the stated range.
By their numbers in this assay, from the lowest: compounds 2, 1 and 3 (each within the scatter of the next).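

In this assay, ethynyl in place of 2-(ethoxycarbonyl)ethyl on a saturated chain carbon bound to a sulfur gives a 1.1-fold higher number from compound 2 to compound 3 (0.05 log units; within the scatter), and ethynyl in place of (ethoxycarbonyl)methyl gives a 1.1-fold higher number from compound 1 to compound 3 (0.02 log units; within the scatter). The earlier step covered only a change of chain length with the ester kept; these steps show that the ester can be absent from this position with the number staying at the level of both ester compounds, so all three stand level. No measurement available here accounts for this flat result.

Going by these compounds, whether any group at this position moves the number beyond the scatter remains open, for example a free carboxylic acid or an amine at the chain end. Also open, on these data alone, is whether a chain longer than 3-(ethoxycarbonyl)propyl stays at the same level.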